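The compounds below may be only part of what the source reports. "The series", "measured", "known", "first", "only" and "open" are said of these compounds alone.

Two compounds built on a shared core have so far been run through a functional assay on NCI-H460 cells (Homo sapiens) for inhibition, read by sulforhodamine B assay, with a stated time of 48 h, tested at 10 uM; a lower number here means less inhibition, a higher number more inhibition at the concentration tested (going by the name of the read-out). Compound 1 `Brc1ccc(-c2cn3ccnc3c(-c3ccc4ncn(C5CCCCC5)c4c3)n2)cc1` gives 13.2% in this assay, while compound 2 `CCc1ccc(-c2cn3ccnc3c(-c3ccc4ncn(Cc5ccccc5)c4c3)n2)cc1` gives 42%. Going by the values given here, compound 2 thus holds the higher of the two numbers, and compound 1, its only neighbour, sits lower by a gap that lies beyond the usual scatter of this measurement. Compound 3 `O=Cc1ccc(-c2cn3ccnc3c(-c3ccc4ncn(Cc5ccccc5)c4c3)n2)cc1` has not yet been measured in this assay. It differs from compound 2 in one place: formyl in place of ethyl on an aromatic carbon. Among the compounds with values here, no pair of measured compounds isolates this change, so nothing measured shows how it acts here. Within the data shown here, with no measured step to rest on, this change is expected to give a number 7 percentage points lower from compound 2 to compound 3 (within the scatter), a shift likely within the scatter and, if anything, downward. Compound 3 is therefore estimated at 35% in this assay, with a range from 10% to 60%.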

Compound 3, a percentage reported as inhibition, at one concentration (the size of the read-out at that concentration, not a potency): 37.8%
The estimate for compound 3 lay 2.8 percentage points below the measured number, within the range that was stated.
By their numbers in this assay, from the lowest: compound 1; then compounds 3 and 2 (each within the scatter of the next).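

In this assay, going by these compounds alone, formyl in place of ethyl on the aromatic carbon para to a large group gives a number 4.2 percentage points lower from compound 2 to compound 3 (within the scatter), the first measured reading of this change. At this place, with the rest of the molecule held constant, the swap from an all-carbon group to one carrying a hydrogen-bond acceptor and a double bond outside the aromatic rings therefore moves the number by no more than the scatter. Nothing measured here explains why the two groups read alike.

From the compounds shown here alone, whether this holds for other groups at this place stays open, for instance an amine, a carboxylic acid or a longer chain such as butyl. Compound 1 differs from compound 2 in more than one place, so the compounds shown do not tell how much each of those changes contributes.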